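One Added Methyl on a Strong Growth Inhibitor

The source may hold more compounds than are shown below. What is called first, only, known or untested is meant among the compounds shown, and "the series" means these compounds.

Compound 1 `Cc1ccnc2nc(-c3cccc(Cl)c3)cc(O)c12`: 31.6 nM
Compound 2 `Cc1ccnc2nc(-c3cccc4ccccc34)cc(O)c12`: < 10 nM (a limit of the assay)

In a functional assay on OVCAR-3 cells (Homo sapiens) for antiproliferative activity (on this read-out lower numbers stand for stronger inhibition of growth and higher numbers for weaker inhibition of growth), compound 1 gives 31.6 nM. Compound 2 gives < 10 nM, which is a limit and not a number. For the measured compounds named here, its exact place on the scale therefore stays open, and no step between these two compounds can be sized.

Compound 3 `Cc1cc(C)c2c(O)cc(-c3cccc4ccccc34)nc2n1` differs from compound 2 in one place: methyl in place of hydrogen on an aromatic carbon. This is a methyl in place of hydrogen on an aromatic carbon, next to the ring nitrogen and meta to a methyl group.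

Going by the values given here, no measured pair here shows what such a change does, so the expectation is a cautious one. It starts from compound 2 at < 10 nM, again a limit. A single methyl is a small change, and the expected result in this assay is an at least 1.2-fold higher number from compound 2 to compound 3 (0.07 log units; that floor lies within the scatter), with little or no move beyond the scatter and a slight lean toward weaker inhibition of growth. The assay may again report only a limit. For compound 3 the estimated value is 12 nM, with an expected range from 4 nM to 50 nM.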

Compound 3, concentration for 50% growth inhibition: 347 nM
Estimate against measurement, compound 3: 29-fold (1.46 log units) below; measured number above the stated range.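

Swapping hydrogen for methyl on this aromatic carbon, next to the ring nitrogen, turns out not to be a small change in this assay: it gives an at least 34-fold higher number from compound 2 to compound 3 (1.54 log units; beyond the scatter). For the compounds shown here, this is the first step that can be sized at all, and it shows that, for this pair, one added carbon at this position is enough to weaken inhibition of growth strongly, a result that compound 1 and compound 2 alone could not reveal. The step is only a floor and the real gap could be wider still, because the starting point of compound 2 is a limit of the assay and not a number: the limit of < 10 nM in this assay, at which 1 of the 3 values shown sits.

The compounds shown do not say why this methyl has so large an effect, or whether the same change would act alike on the core of compound 1, with its chlorine-bearing ring in place of the larger ring system of compound 2. As far as these compounds go, it also stays open whether another group on this carbon, such as a fluorine, a methoxy group or an amine, would be tolerated better or fare just as badly.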